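Chalcone Aryl Swap: Dimethylamino Out, Nitro In

The source may report more compounds than this note shows. Statements on the series, on what has been measured and on what is new or still open speak of the compounds shown alone.

Compound 1 `COc1cccc(/C=C/C(=O)c2ccc(OC)c3c2OC(C)(C)C=C3)c1` gives > 10000 nM in a functional assay on SW-620 cells (Homo sapiens) for antiproliferative activity, read by MTT assay, with a stated time of 24 h (on this read-out higher numbers stand for weaker inhibition and lower numbers for stronger inhibition), which is a limit of this assay rather than a number.
Compound 2 `COc1ccc(/C=C/C(=O)c2ccc(OC)c3c2OC(C)(C)C=C3)c(F)c1` gives 6570 nM in this assay.
Compound 3 `COc1ccc(C(=O)/C=C/c2ccc(N(C)C)cc2)c2c1C=CC(C)(C)O2` gives 570 nM in this assay.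

Compound 3 stands at the lowest of the two numbers measured; its nearest neighbour is compound 2, and the step of a 12-fold lower number from compound 2 to compound 3 (1.06 log units; beyond the scatter) lies beyond the scatter. Compound 1 rests at the limit of > 10000 nM in this assay, at which 1 of the 3 values shown sits, and the step of an at least 17-fold lower number from compound 1 to compound 3 (1.24 log units; beyond the scatter) is at least as large. The step of an at least 1.5-fold lower number from compound 1 to compound 2 (0.18 log units; that floor lies within the scatter) stays within the scatter.

Compound 4 `COc1ccc(C(=O)/C=C/c2cccc([N+](=O)[O-])c2)c2c1C=CC(C)(C)O2` differs from compound 3 by 3-nitrophenyl in place of 4-(dimethylamino)phenyl on a double-bonded chain carbon bound to a double-bonded chain carbon. Both large steps toward compound 3 coincide with the arrival of the 4-(dimethylamino)phenyl; compound 4 gives that group up. The number for compound 4 is therefore expected to rise, by about a 12-fold higher number from compound 3 to compound 4 (1.09 log units; beyond the scatter), toward the values of compound 1 and compound 2. Compound 4 is estimated at 7000 nM, in the range 1500 nM to 20000 nM, with a real chance that only a limit is reported.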

Compound 4, half-maximal inhibitory concentration: 4090 nM
The estimate for compound 4 lay 1.7-fold (0.23 log units) above the measured number, within the range that was stated.
By their numbers in this assay, from the lowest: compound 3; then compounds 4 and 2 (each within the scatter of the next). At a limit, above all of these: compound 1.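

At this place on the chain, 3-nitrophenyl does not keep what 4-(dimethylamino)phenyl reached in this assay (a 7.2-fold higher number from compound 3 to compound 4 (0.86 log units; beyond the scatter)), and it cannot be told apart from 2-fluoro-4-methoxyphenyl (a 1.6-fold lower number from compound 2 to compound 4 (0.21 log units; within the scatter)). Nitro in place of methoxy on an aromatic carbon still registers (an at least 2.4-fold lower number from compound 1 to compound 4 (0.38 log units; beyond the scatter)). That step is only a floor, for compound 1 sits at a limit: the limit of > 10000 nM in this assay, at which 1 of the 4 values shown sits.

Left open is whether a pyrrolidine or a plain amino group on the phenyl would keep the low number of compound 3, and whether 4-nitrophenyl would read like 3-nitrophenyl.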